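A longer side arm on a shared core

The compounds below may be only part of what the source reports. "The series", "measured", "known", "first", "only" and "open" are said of these compounds alone.

Measured so far:
compound 1, `CNC(=O)CCn1nc(-c2ccccc2)ccc1=O` — 3.5%
compound 2, `N=C(S)Cn1nc(-c2ccccc2)ccc1=O` — 5.5%

Both compounds were tested in a functional assay on the whole organism (stomach) for inhibition, with Rattus norvegicus as the target, at a dose of 100 mg/kg by the intraduodenal route; on this read-out lower numbers stand for less inhibition and higher numbers for more inhibition at the one dose given (going by the name of the read-out). Compound 2 gives 5.5%, the higher of the two numbers, though only barely. Its nearest neighbour, compound 1, gives 3.5%. The step between them, a number 2 percentage points higher from compound 1 to compound 2 (within the scatter), shows that exchanging the whole side arm on the saturated chain carbon bound to the aromatic nitrogen left the read-out essentially where it was.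

Compound 3, `CC(Cn1nc(-c2ccccc2)ccc1=O)C(=N)S`, has not been measured yet. It differs from compound 2 at that same place: a group of 5 heavy atoms (3 carbon, 1 nitrogen, 1 sulfur; no ring) in place of a group of 3 heavy atoms (1 carbon, 1 nitrogen, 1 sulfur; no ring), on a saturated chain carbon bound to an aromatic nitrogen.

For the measured compounds named here, only one measured step bears on this change, and it sits at the same position: a number 2 percentage points higher from compound 1 to compound 2 (within the scatter), a change that stayed within the scatter. Nothing seen here suggests that growing the side arm will move the number far. The expected step is therefore a number 0.5 percentage points higher from compound 2 to compound 3 (within the scatter), with no direction claimed beyond the scatter. Compound 3 is estimated to give 6%, most likely somewhere between 0% and 16%.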

Compound 3, a percentage reported as inhibition, in the whole organism at one dose (the size of the read-out at that dose, not a potency): 86.4%
For compound 3 the middle estimate is 80.4 percentage points below the measured one; measured number outside the range, above it.
By their numbers in this assay, from the lowest: compounds 1 and 2 (each within the scatter of the next); then compound 3.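

In this assay, the side arm on a saturated chain carbon bound to an aromatic nitrogen can clearly decide the outcome, which the first two compounds gave no sign of: replacing the group of 3 heavy atoms with the group of 5 heavy atoms gives a number 80.9 percentage points higher from compound 2 to compound 3 (beyond the scatter), although the two groups match in hydrogen-bond donors, hydrogen-bond acceptors and net charge. Heavy-atom count alone does not settle the matter either, since the side arms of compound 1 and compound 3 are both groups of 5 heavy atoms, one holding oxygen and the other sulfur, and the result is a number 82.9 percentage points higher from compound 1 to compound 3 (beyond the scatter). No measurement shown offers an explanation for these large steps.

The compounds shown leave open whether the gain follows the added carbon atoms, the sulfur-bearing end of the arm or the two together, and a longer chain or an unbranched chain ending in the same group would help separate these. A carboxylic acid or an amine at the end of the arm would show how much that end can vary, while readings at other doses would show whether the large number at this one dose reflects potency.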